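Thiophen-2-yl amide in the chalcone series

The source may hold more compounds than are shown below. What is called first, only, known or untested is meant among the compounds shown, and "the series" means these compounds.

Three compounds of the shared core have numbers in a functional assay on HUVEC cells (Homo sapiens) for inhibition; on this read-out higher numbers stand for weaker inhibition and lower numbers for stronger inhibition. Compound 3 `CCOC(=O)C(=O)Nc1cccc(C(=O)/C=C/c2ccc(O)c(OC)c2)c1` gives 13.3 ug/mL, the highest of the three. Compound 1 `COc1cc(/C=C/C(=O)c2cccc(NC(=O)c3ccc(Cl)c(Cl)c3)c2)ccc1O` gives 2.97 ug/mL and compound 2 `COc1cc(/C=C/C(=O)c2cccc(NC(=O)c3ccccc3)c2)ccc1O` gives 0.37 ug/mL. The steps are an 8.0-fold lower number from compound 1 to compound 2 (0.90 log units; beyond the scatter), a 4.5-fold higher number from compound 1 to compound 3 (0.65 log units; beyond the scatter) and a 36-fold higher number from compound 2 to compound 3 (1.56 log units; beyond the scatter).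

Compound 4 `COc1cc(/C=C/C(=O)c2cccc(NC(=O)c3cccs3)c2)ccc1O` is the next entry. Against compound 3 the change is thiophen-2-yl in place of ethoxycarbonyl on a carbonyl carbon. As in compound 2, a ring now sits on the carbonyl carbon whose other neighbour is the amide-type nitrogen, in place of the ethoxycarbonyl chain of compound 3.

Among the compounds with values here, the steps that bear on this are those that remove or introduce the ethoxycarbonyl: the large step of a 36-fold higher number from compound 2 to compound 3 (1.56 log units; beyond the scatter) and the modest step of a 4.5-fold higher number from compound 1 to compound 3 (0.65 log units; beyond the scatter). On these data alone, both point the same way when read from compound 3 outward, so a lower number is expected, probably of a size between those two, though the thiophen-2-yl itself is untested here. For compound 4 the estimate is 0.6 ug/mL, with a range of 0.2 ug/mL to 2 ug/mL, meaning an expected step of a 22-fold lower number from compound 3 to compound 4 (1.35 log units; beyond the scatter).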

Compound 4, half-maximal inhibitory concentration: 0.38 ug/mL
The estimate for compound 4 lay 1.6-fold (0.20 log units) above the measured number, within the range that was stated.
By their numbers in this assay, from the lowest: compounds 2 and 4 (each within the scatter of the next); then compound 1; then compound 3.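

In this assay, thiophen-2-yl on the carbonyl carbon whose other neighbour is the amide-type nitrogen stands well apart from the ethoxycarbonyl chain (a 35-fold lower number from compound 3 to compound 4 (1.54 log units; beyond the scatter)) and also from 3,4-dichlorophenyl (a 7.8-fold lower number from compound 1 to compound 4 (0.89 log units; beyond the scatter)). Against phenyl the exchange stays within the scatter (a 1.0-fold higher number from compound 2 to compound 4 (0.01 log units; within the scatter)), so this position now holds two unsubstituted aromatic rings at one level, and phenyl is no longer the only ring known to give a low number here. The compounds shown offer no measurement that explains these steps.

Open, on these data alone, is whether chlorine on the thiophen-2-yl ring would raise the number as 3,4-dichlorophenyl does relative to phenyl. Also open, as far as these compounds go, is how a saturated ring such as piperidine, or a chain ending in a carboxylic acid or an amine, would compare at this carbonyl carbon.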